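Selenocyanate Returns on a Longer Side Chain

A few compounds are considered here, and "the series" means these few. Any claim that something is new, unique, unknown or untested is made for them only; others in the source may bear on it.

Two compounds set the scene in a functional assay on LoVo cells (Homo sapiens) for inhibition, read by MTT assay, with a stated time of 48 h; a lower number here means a stronger inhibitor, a higher number a weaker inhibitor. Compound 1 `Cc1nc(N(C)c2ccc([Se]C#N)c(Cl)c2)c2ccccc2n1` carries a selenocyanate and gives 12 nM. Compound 2 `COc1ccc(N(C)c2nc(C)nc3ccccc23)cc1OCCN`, which carries no selenium, gives 421 nM in this assay; that is the higher of the two numbers, and its gap from compound 1 lies beyond the usual scatter. Compound 3 `COc1ccc(N(C)c2nc(C)nc3ccccc23)cc1C(=O)NCC[Se]C#N` has not been measured. It differs from compound 2 in one place: a group of 8 heavy atoms (4 carbon, 2 nitrogen, 1 oxygen, 1 selenium; no ring) in place of a group of 4 heavy atoms (2 carbon, 1 nitrogen, 1 oxygen; no ring), on an aromatic carbon. A selenocyanate is thus brought back, now borne on a chain rather than as in compound 1. Since compound 1 gives 12 nM while compound 2 gives 421 nM, a downward step is expected. The group enters on a chain, so only a moderate step is expected, a 3.8-fold lower number from compound 2 to compound 3 (0.58 log units; beyond the scatter). Compound 3 is therefore estimated at 110 nM, within a range of 25 nM to 450 nM.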

Compound 3, half-maximal inhibitory concentration: 561 nM
Estimate against measurement, compound 3: 5.1-fold (0.71 log units) below, outside the stated range (above it).
By their numbers in this assay, from the lowest: compound 1; then compounds 2 and 3 (each within the scatter of the next).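

On this aromatic carbon, ortho to a methoxy group, exchanging the 2-aminoethoxy group for the selenocyanate-bearing chain gives a 1.3-fold higher number from compound 2 to compound 3 (0.12 log units; within the scatter) in this assay. Compound 2 and compound 3 therefore cannot be told apart in this assay, so this pair shows that a selenocyanate on this chain at this position can be present with no resolved difference from the 2-aminoethoxy group. No accompanying measurement bears on this result, so it stands without explanation.

The compounds shown leave open whether a selenocyanate placed directly on this aromatic carbon, without the chain, would separate from compound 2. They also leave open whether a longer chain ending in selenocyanate, or a chain ending in a nitrile or a carboxylic acid, would do so at this position.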